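The source may report more compounds than this note shows. Statements on the series, on what has been measured and on what is new or still open speak of the compounds shown alone.

In a functional assay on MCF7 cells (Homo sapiens) for inhibition, read by MTT assay, with a stated time of 3 days (a higher number here means a weaker inhibitor, a lower number a stronger inhibitor), compound 1 (`COc1cc(-c2nc3ccccc3s2)ccc1OCC(=O)NNC(=O)CCl`) gives 780 nM, compound 2 (`COc1cc(-c2nc3ccccc3s2)ccc1OCC(=O)NNC(=O)CN(C(C)=O)[C@@H](CS)C(=O)O`) gives 1750 nM and compound 3 (`COc1cc(-c2nc3ccccc3s2)ccc1OCC(=O)NNC(=O)CN1CCC[C@H]1C(=O)O`) gives 840 nM. The place of compound 3 among these numbers is firm on only one side, as the two steps show: a 1.1-fold higher number from compound 1 to compound 3 (0.03 log units; within the scatter), and a 2.1-fold lower number from compound 2 to compound 3 (0.32 log units; beyond the scatter).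

Compound 4 (`CCOC(=O)[C@@H](NCC(=O)NNC(=O)COc1ccc(-c2nc3ccccc3s2)cc1OC)[C@@H](C)CC`) carries (1-(ethoxycarbonyl)-2-methylbutyl)amino in place of 2-carboxypyrrolidin-1-yl on a saturated chain carbon bound to a carbonyl carbon, and the exchange amounts to (1-(ethoxycarbonyl)-2-methylbutyl)amino in place of 2-carboxypyrrolidin-1-yl on a saturated chain carbon bound to a carbonyl carbon. Within the data shown here, no measured step makes this exact exchange. The closest evidence comes from the other changes at the same place, which have all stayed small, the largest being a 2.2-fold higher number from compound 1 to compound 2 (0.35 log units; beyond the scatter). A shift beyond the scatter in this assay is therefore not expected, and these three compounds point to no clear direction. The expected change is a 1.1-fold lower number from compound 3 to compound 4 (0.02 log units; within the scatter). For compound 4 the estimated value is 800 nM, with an expected range of 350 nM to 1900 nM.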

Compound 4, half-maximal inhibitory concentration: 1950 nM
Estimate against measurement, compound 4: 2.4-fold (0.39 log units) below; measured number outside the range, above it.
By their numbers in this assay, from the lowest: compounds 1 and 3 (each within the scatter of the next); then compounds 2 and 4 (each within the scatter of the next).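

In this assay, the place on a saturated chain carbon bound to a carbonyl carbon does not tolerate every exchange equally: (1-(ethoxycarbonyl)-2-methylbutyl)amino gives a 2.3-fold higher number from compound 3 to compound 4 (0.37 log units; beyond the scatter) and a 2.5-fold higher number from compound 1 to compound 4 (0.40 log units; beyond the scatter), steps of modest size. Set against acetyl(1-carboxy-2-sulfanylethyl)amino, the same group gives a 1.1-fold higher number from compound 2 to compound 4 (0.05 log units; within the scatter), so the four compounds now fall into two pairs, compounds 1 and 3 on the lower side and compounds 2 and 4 on the higher. Nothing at hand explains this split.

The exchange from compound 3 to compound 4 opens the ring and brings in the ethyl ester together, so the compounds shown leave open which of the two changes goes with the step. A (1-carboxy-2-methylbutyl)amino group, the carboxylic acid of the same chain, would separate them.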